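Removing the sulfonamide from compound 2: an aniline analogue

The compounds below may be only part of what the source reports. "The series", "measured", "known", "first", "only" and "open" are said of these compounds alone.

Compound 2 `COc1ccc(CCCCCCCCOc2ccc(CSc3cccc(NS(=O)(=O)C(F)(F)F)c3)nc2/C=C/C(=O)O)cc1` stands at the higher of the two numbers recorded in an assay for binding affinity to leukotriene B4 receptor 1 (Homo sapiens) (a higher number here means a weaker inhibitor, a lower number a stronger inhibitor), giving 284 nM, while compound 1 `COc1ccc(CCCCCCCCOc2ccc(C[S+]([O-])c3ccccc3)nc2/C=C/C(=O)O)cc1` gives 37 nM in this assay, a gap beyond the scatter. Compound 3 `COc1ccc(CCCCCCCCOc2ccc(CSc3cccc(N)c3)nc2/C=C/C(=O)O)cc1` differs from compound 2 only by hydrogen in place of (trifluoromethyl)sulfonyl on a nitrogen on an aromatic ring. Within the data shown here, no step of this exact kind has been measured here, so the size of the effect in this assay is open. He expects the step of a 1.6-fold lower number from compound 2 to compound 3 (0.20 log units; within the scatter) to be small, likely within the scatter, and possibly slightly toward a weaker inhibitor. Compound 3 is therefore estimated at 180 nM, within a range of 50 nM to 650 nM.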

Compound 3, inhibition constant: 34 nM
For compound 3 the middle estimate is 5.3-fold (0.72 log units) above the measured one, outside the stated range (below it).
By their numbers in this assay, from the lowest: compounds 3 and 1 (each within the scatter of the next); then compound 2.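

In this assay, taking the (trifluoromethyl)sulfonyl off the nitrogen on the aromatic ring gives an 8.4-fold lower number from compound 2 to compound 3 (0.92 log units; beyond the scatter), so this position responds strongly to the change and the group is no neutral passenger. The step of a 1.1-fold lower number from compound 1 to compound 3 (0.04 log units; within the scatter) puts the aniline level with compound 1 , and the gap seen earlier closes within the scatter. Nothing available here explains this step.

The compounds shown leave open whether the free amino group itself matters or only the loss of the sulfonyl. A methanesulfonyl group or an acetyl group on that nitrogen, or a hydroxyl in place of the amino group, would tell these apart.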